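Swapping an Acetylpiperazine for Piperidine in a Nitrile Series

The compounds below may be only part of what the source reports. "The series", "measured", "known", "first", "only" and "open" are said of these compounds alone.

Compound 1, `CC(C)(C)CNc1nc(C#N)ncc1C#CCN1Cc2ccccc2C1`: 920 nM in an assay on isolated protein for inhibition of cathepsin S (Homo sapiens), read by fluorescence; on this read-out higher numbers stand for weaker inhibition and lower numbers for stronger inhibition
Compound 2, `CC(C)(C)CNc1nc(C#N)ncc1C#CCN1CCc2ccccc2C1`: 840 nM
Compound 3, `CC(=O)N1CCN(CC#Cc2ccc(CN(CC(C)(C)C)c3ccnc(C#N)n3)cc2)CC1`: > 1000 nM

Compound 1 and compound 2 give numbers that lie within the usual scatter of each other, so no order between them can be read. For compound 3 the read-out is not a number but a limit, > 1000 nM. Compound 3 therefore stands at the limit of > 1000 nM in this assay, at which 1 of the 3 values shown sits, the weakest end of what is shown, with no measured step connecting it to compound 1 or compound 2, since its shared core is built differently.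

Compound 4, `CC(C)(C)CN(Cc1ccc(C#CCN2CCCCC2)cc1)c1ccnc(C#N)n1`, is the not yet measured partner of compound 3. The difference between the two is piperidin-1-yl in place of 4-acetylpiperazin-1-yl on a saturated chain carbon bound to a triple-bonded carbon. Because compound 3 gives only the limit > 1000 nM, no measured step can say how this kind of change plays out, and no other pair shown carries the same change.

With nothing beyond the limit of compound 3 to build on, the expected step is a step that the limit leaves unreadable from compound 3 to compound 4, that is, no move clearly beyond the scatter, with a real chance that only a limit is reported again. Compound 4 is expected to give about 1500 nM, somewhere between 400 nM and 6000 nM.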

Compound 4, half-maximal inhibitory concentration: > 1000 nM
Compound 4: a limit, no number; the forecaster's own chance of this, stated with the estimate: 55%; the middle value does not contradict the limit.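

In this assay compound 4 gives > 1000 nM as a limit, not a number. Compound 3 gives > 1000 nM as a limit too. For the compounds shown here, no step between compound 3 and compound 4 can be read: the limit of > 1000 nM in this assay, at which 2 of the 4 values shown sit. As far as these compounds go, what stays open is how strongly either compound inhibits, and whether piperidin-1-yl in place of 4-acetylpiperazin-1-yl changes that at all.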